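The source may report more compounds than this note shows. Statements on the series, on what has been measured and on what is new or still open speak of the compounds shown alone.

Measured in a functional assay on Jurkat cells (Homo sapiens) for cytotoxicity, with a stated time of 72 h; on this read-out higher numbers stand for an effect only at larger amounts of compound and lower numbers for an effect already at smaller amounts:
- compound 1 `COc1ccc(/C=C/[C@@](C)(/C=C/c2ccc(O)c(/C=C/C(=O)OC(C)(C)C)c2)CCC=C(C)C)cc1` gives > 49000 nM
- compound 2 `COc1ccc(/C=C/[C@@](C)(/C=C/c2ccc(O)c(/C=C/C(C)=O)c2)CCC=C(C)C)cc1` gives > 49000 nM
- compound 3 `COc1ccc(/C=C/[C@@](C)(/C=C/c2ccc(O)cc2)CCC=C(C)C)cc1` gives > 49000 nM

All three entries are limits of the assay and not numbers, as the limit of > 49000 nM in this assay, at which 3 of the 3 values shown sit, records. Compound 3 therefore has no number to stand on, only its limit of > 49000 nM.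

Compound 4 `CCOc1ccc(/C=C/[C@@](C)(/C=C/c2ccc(O)cc2)CCC=C(C)C)cc1` follows from compound 3 through (methyl in place of hydrogen on a saturated chain carbon bound to an oxygen on an aromatic ring), that is, methyl in place of hydrogen on a saturated chain carbon bound to an oxygen on an aromatic ring, or methoxy to ethoxy. Within the data shown here, none of the measured steps changes this place. They give no size to carry over: a step that the two limits leave unreadable from compound 1 to compound 2, a step that the two limits leave unreadable from compound 1 to compound 3 and a step that the two limits leave unreadable from compound 2 to compound 3. The expectation rests only on the shared limit, and no step beyond the scatter is expected in this assay, in either direction. The expected result is a number no higher from compound 3 to compound 4 (the limit leaves the size open). Compound 4 is estimated at 49000 nM, with an expected range from 20000 nM to 100000 nM.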

Compound 4, half-maximal effective concentration: > 49000 nM
Compound 4 ended at the assay's limit (the forecaster's own chance of this, stated with the estimate: 80%); the middle value lies on the limit itself.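

Compound 3 and compound 4 both stand at a limit and not at a number, so no step between them can be read in this assay: the limit of > 49000 nM in this assay, at which 4 of the 4 values shown sit.

In this assay the compounds shown leave open how large the methoxy to ethoxy step is, and whether any of these four structures gives a measurable effect.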